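A limit-bound pair and the step to compound 3

The compounds below may be only part of what the source reports. "The series", "measured", "known", "first", "only" and "open" are said of these compounds alone.

In a physicochemical assay for lipophilicity, at pH 7.4 (a higher number here means a more lipophilic compound, a lower number a more polar compound), compound 1 (`Cc1cc(C(=O)NC(C)C)nn1Cc1cc(Cl)ccc1OCc1ccccc1`) gives > 3.7, which is a limit and not a number. Compound 2 (`Cc1cc(C(=O)NCc2ccncc2)nn1Cc1cc(Cl)ccc1OCc1ccccc1`) gives > 3.7, also only a limit. Going by the values given here, the one measured step, a step that the two limits leave unreadable from compound 1 to compound 2, therefore has no readable size. Compound 3 (`Cc1cc(NC(=O)CC(C)(C)C)nn1Cc1cc(Cl)ccc1OCc1ccccc1`) carries (neopentylcarbonyl)amino in place of ((pyridin-4-yl)methyl)carbamoyl on an aromatic carbon. Compound 2 shares (the limit of > 3.7 in this assay, at which 2 of the 2 values shown sit), which offers no measured size to carry over. Only a modest upward move is expected, with the estimated step being a step that the limit leaves unreadable from compound 2 to compound 3. Compound 3 is estimated at 4.1, within an expected range of 3.6 to 4.7.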

Compound 3, distribution coefficient: > 3.7
Compound 3: no number, only a limit; the forecaster's own chance of this, stated with the estimate: 70%; the middle value lies beyond the limit too.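

Compound 3 also gives only a limit in this assay, so no step among compound 1, compound 2 and compound 3 can be read: the limit of > 3.7 in this assay, at which 3 of the 3 values shown sit.

The compounds shown leave open how these three actually compare in this assay.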